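Trimethoxyphenyl pyrazoline carbamates: hydroxy on the phenyl ring

This account rests on a few compounds, and the source may have more. Where it says the series, first, only, none or still open, it means among the compounds named here.

Measured so far in a functional assay on MDA-MB-231 cells (Homo sapiens) for antiproliferative activity, read by MTT assay, with a stated time of 48 h; on this read-out higher numbers stand for weaker inhibition of growth and lower numbers for stronger inhibition of growth:
compound 1, `COC(=O)N1N=C(c2ccccc2)CC1c1cc(OC)c(OC)c(OC)c1`: 1080 nM
compound 2, `CCCOC(=O)N1N=C(c2ccccc2)CC1c1cc(OC)c(OC)c(OC)c1`: 14400 nM

Among the measured compounds shown here, compound 1 gives the lowest of the two numbers; the sole neighbour, compound 2, differs by a 13-fold higher number from compound 1 to compound 2 (1.12 log units; beyond the scatter), a change on the ester chain only. Compound 3, `COC(=O)N1N=C(c2cccc(O)c2)CC1c1cc(OC)c(OC)c(OC)c1`, departs from compound 1 elsewhere: hydroxy in place of hydrogen on an aromatic carbon. For the measured compounds named here, no measured step touches the phenyl ring, so the ester-chain step gives no guidance here and the change is taken as neutral. A step within the scatter is therefore expected, a 1.4-fold lower number from compound 1 to compound 3 (0.13 log units; within the scatter), and compound 3 is estimated at 800 nM, within 250 nM to 2500 nM.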

Compound 3, concentration for 50% growth inhibition: 740 nM
Beside the measured number, compound 3's estimate is 1.1-fold (0.03 log units) above it; the range from low to high includes it.
By their numbers in this assay, from the lowest: compounds 3 and 1 (each within the scatter of the next); then compound 2.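

In this assay, among the compounds shown here, phenyl to 3-hydroxyphenyl gives a 1.5-fold lower number from compound 1 to compound 3 (0.16 log units; within the scatter), the only reading so far on the phenyl ring rather than on the ester chain. This place on the ring therefore tolerates hydroxy with no change beyond the scatter, unlike the large ester-chain step, a 13-fold higher number from compound 1 to compound 2 (1.12 log units; beyond the scatter). No measurement at hand speaks to the reason for this result.

On these data alone, whether a methoxy group, an amine or a fluorine at this place would read the same remains open. Also open, as far as these compounds go, is how hydroxy behaves on the other carbons of the ring.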